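A few compounds are considered here, and "the series" means these few. Any claim that something is new, unique, unknown or untested is made for them only; others in the source may bear on it.

Measured compounds, all in an ADME assay on HepG2 2.2.15 cells (Homo sapiens) for cytotoxicity; on this read-out lower numbers stand for stronger inhibition and higher numbers for weaker inhibition:

compound 1, `CC1(C)CC(=O)C2=C(C1)NC(c1cnccn1)=NC2c1ccc(F)cc1Cl`, gives 773000 nM
compound 2, `CC1(C)CC(=O)C2=C(C1)NC(c1cnccn1)=NC2c1ccccc1Cl`, gives 623000 nM
compound 3, `CC1(C)CC(=O)C2=C(C1)NC(c1cccnc1)=NC2c1ccc(F)cc1`, gives 145000 nM

Compound 1 and compound 2 share one core and differ in a single spot; compound 3 has a different core, and the difference between the core of compound 1 and the core of compound 3 is not broken down here. Of the three, compound 3 gives the lowest number, and its distance from both compound 2 and compound 1 is beyond the usual scatter of this assay.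

Compound 4, `CC1(C)CC(=O)C2=C(C1)NC(c1cccnc1)=NC2c1ccccc1`, has not yet been measured. It is made from compound 3 by one change: hydrogen in place of fluoro on an aromatic carbon. The same kind of change has already been seen once, from compound 1 to compound 2: hydrogen in place of fluoro on an aromatic carbon. The two places are not identical: in the earlier pair the carbon that loses the fluoro is also meta to a chloro group, while in compound 3 no such group sits on that ring. In this assay the earlier change produced a 1.2-fold lower number from compound 1 to compound 2 (0.09 log units; within the scatter), a step too small to be told apart from repeat measurements.

Resting on that single precedent, the step from compound 3 to compound 4 is expected to be similarly small, about a 1.1-fold lower number from compound 3 to compound 4 (0.05 log units; within the scatter). Compound 4 is therefore estimated at 130000 nM, with a likely range from 65000 nM to 260000 nM.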

Compound 4, half-maximal inhibitory concentration: 173000 nM
For compound 4 the middle estimate is 1.3-fold (0.12 log units) below the measured one; low and high end bracket the measured number.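

In this assay, putting hydrogen in place of the fluoro gives a 1.2-fold higher number from compound 3 to compound 4 (0.08 log units; within the scatter), so the 4-fluorophenyl compound and the phenyl compound on this core cannot be told apart. Set beside the earlier case, the change behaves alike on the two cores: the same change on two cores in this assay, a 1.2-fold lower number (0.09 log units; within the scatter) from compound 1 to compound 2 and a 1.2-fold higher number (0.08 log units; within the scatter) from compound 3 to compound 4, 1.5-fold (0.17 log units) apart, within the scatter of two such steps. This shows that the swap left no readable mark at either place, but it rests on two pairs in one assay, and the earlier pair also carries a chloro group on that ring while compound 3 carries none, so it does not show that the same would hold on a further core or in a different test.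

The compounds shown leave open whether a different group at that place, such as a methoxy, an amine or a carboxylic acid, would move the number beyond the usual scatter, given that only fluoro and hydrogen appear there. No pair shown differs by the chloro group alone, and none differs only in the rest of the core, so what either of those parts does on its own in this series also stays open.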